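Same atoms, rearranged side chain: compound 2 to compound 3

A few compounds are considered here, and "the series" means these few. Any claim that something is new, unique, unknown or untested is made for them only; others in the source may bear on it.

In an ADME assay on L6 cells (Rattus norvegicus) for cytotoxicity, read by resazurin assay, with a stated time of 72 h (a higher number here means a weaker inhibitor, a lower number a stronger inhibitor), compound 1 `CN1CCN(CCC(=O)N2CC3C(c4ccccc4)CC(N(C)C)(CC3c3ccccc3)C2)CC1` gives 13000 nM and compound 2 `CN(C)C12CC(c3ccccc3)C(CN(CCN3CCCCC3)C1)C(c1ccccc1)C2` gives 2920 nM, the lower of the two numbers. For the measured compounds named here, the only measured step is a 4.5-fold lower number from compound 1 to compound 2 (0.65 log units; beyond the scatter), and it replaces a different group, so it bears on the next change only loosely. Compound 3 `CN(C)C12CC(c3ccccc3)C(CN(CCCN3CCCC3)C1)C(c1ccccc1)C2` holds the same atoms as compound 2, joined differently: (pyrrolidin-1-yl)methyl in place of piperidin-1-yl on a saturated chain carbon, two bonds along the chain from an amine nitrogen in a ring. Going by the values given here, no measured step covers this swap, so the expected step is small and stays within the scatter: a 1.2-fold higher number from compound 2 to compound 3 (0.08 log units; within the scatter). Compound 3 is estimated at 3500 nM, with an expected range from 1400 nM to 9000 nM.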

Compound 3, half-maximal inhibitory concentration: 1550 nM
Beside the measured number, compound 3's estimate is 2.3-fold (0.35 log units) above it; measured number inside the range.
By their numbers in this assay, from the lowest: compounds 3 and 2 (each within the scatter of the next); then compound 1.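

In this assay, swapping 2-(piperidin-1-yl)ethyl for 3-(pyrrolidin-1-yl)propyl on an amine nitrogen in a ring gives a 1.9-fold lower number from compound 2 to compound 3 (0.28 log units; within the scatter), so this rearrangement of the same atoms does not separate the two compounds. Replacing (2-(4-methylpiperazin-1-yl)ethyl)carbonyl with 3-(pyrrolidin-1-yl)propyl gives an 8.4-fold lower number from compound 1 to compound 3 (0.92 log units; beyond the scatter), so compounds 2 and 3 both stand clear of compound 1. Nothing available explains these numbers. As far as these compounds go, whether the carbonyl or the 4-methylpiperazine sets compound 1 apart remains open, as does the effect of a morpholine or a longer chain at this nitrogen.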